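Replacing the nitroanilinomethyl arm of compound 1 by benzamido

A few compounds are considered here, and "the series" means these few. Any claim that something is new, unique, unknown or untested is made for them only; others in the source may bear on it.

Among the measured compounds shown here, compound 1 `N#CN/C(=N\CCCNc1ccccc1[N+](=O)[O-])NCCCCOc1cccc(CN2CCCCC2)c1` stands highest of the two numbers known: in a functional assay on cardiac atrium for antagonist activity at histamine H2 receptor (Cavia porcellus) (on this read-out lower numbers stand for lower potency and higher numbers for higher potency (the scale is a negative logarithm)), compound 1 gives 7.85, whereas compound 2 `N#CN/C(=N\CCCNc1ccc(N=[N+]=[N-])cc1[N+](=O)[O-])NCCCCOc1cccc(CN2CCCCC2)c1` gives 6.56, the step being a number 1.29 log units lower from compound 1 to compound 2 (beyond the scatter). Compound 3 `N#CN/C(=N\CCNC(=O)c1ccccc1)NCCCCOc1cccc(CN2CCCCC2)c1` differs from compound 1 by benzamido in place of ((2-nitrophenyl)amino)methyl on a saturated chain carbon, two bonds along the chain from a double-bonded nitrogen. For the measured compounds named here, no measured step bears directly on this change; the only known step concerns an azido group at another place, which offers no guidance for the chain exchange. The expected step is a number 0.85 log units lower from compound 1 to compound 3 (beyond the scatter), a moderate move downward. Compound 3 is therefore estimated at 7, within a range from 6.3 to 7.7.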

Compound 3, negative logarithm of the antagonist equilibrium constant: 7.67
Compound 3: the middle estimate sits 0.67 log units below what was measured; the measured number falls inside the stated range.
By their numbers in this assay, from the lowest: compound 2; then compounds 3 and 1 (each within the scatter of the next).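

In this assay, benzamido in place of ((2-nitrophenyl)amino)methyl on this saturated chain carbon gives a number 0.18 log units lower from compound 1 to compound 3 (within the scatter). The position therefore tolerates this exchange of the whole arm, and the nitro-bearing aniline of compound 1 can be given up without a step beyond the scatter. Nothing available explains why the two arms read alike.

As far as these compounds go, it remains open whether an azido group on the benzamido ring of compound 3 would lower the number as it does in compound 2. Also open, from the compounds shown here alone, is how a phenylacetamido or phenylurea arm would read at this position.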